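The compounds below may be only part of what the source reports. "The series", "measured", "known", "first", "only" and "open" are said of these compounds alone.

Measured in a functional assay on A20 cells (Mus musculus) for inhibition, with stated times of 1 h, 16 h and 24 h; on this read-out higher numbers stand for weaker inhibition and lower numbers for stronger inhibition:

- compound 1 `N#CCNC(=O)[C@@H]1C[C@@H](S(=O)(=O)CC2CC2)C[C@H]1C(=O)N1CCOCC1`: 4510 nM
- compound 2 `N#CCNC(=O)[C@@H]1C[C@@H](S(=O)(=O)c2ccccc2Cl)C[C@H]1C(=O)N1CCOCC1`: 3 nM
- compound 3 `N#CC1(NC(=O)[C@@H]2C[C@@H](S(=O)(=O)c3ccccc3)C[C@H]2C(=O)N2CCOCC2)CC1`: 12 nM

At 12 nM, compound 3 is the second highest of the three numbers. Compound 4 `CN1CCN(C(=O)[C@@H]2C[C@H](S(=O)(=O)c3ccccc3)C[C@H]2C(=O)NC2(C#N)CC2)CC1` differs from it by 4-methylpiperazin-1-yl in place of morpholin-4-yl on a carbonyl carbon. For the measured compounds named here, the one measured step, a 1500-fold lower number from compound 1 to compound 2 (3.18 log units; beyond the scatter), is a change on a sulfonyl sulfur. It does not touch this place, so it gives no guide to size or direction here. Going by the values given here, no measured pair varies the group on the carbonyl carbon. With no evidence for a shift, no step beyond the scatter is expected in this assay. The estimated step is a 1.2-fold lower number from compound 3 to compound 4 (0.08 log units; within the scatter). Compound 4 is expected at 10 nM, with an estimated range of 3 nM to 35 nM.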

Compound 4, half-maximal inhibitory concentration: 17 nM
Compound 4: middle estimate off by 1.7-fold (0.23 log units), on the low side, and the stated range covers the measured number.
By their numbers in this assay, from the lowest: compound 2; then compounds 3 and 4 (each within the scatter of the next); then compound 1.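

In this assay, for the compounds shown here, the first measured pair at this place gives a 1.4-fold higher number from compound 3 to compound 4 (0.15 log units; within the scatter) for 4-methylpiperazin-1-yl in place of morpholin-4-yl on a carbonyl carbon. This exchange of one six-membered ring with 2 hetero atoms for another therefore leaves the read-out within the scatter, unlike the large step seen on the sulfonyl sulfur. Nothing available explains this result.

Still open, on these data alone, is whether an open-chain dimethylamino group or a piperidine carrying a carboxylic acid on this carbonyl carbon would also stay within the scatter. Also open, as far as these compounds go, is whether the same exchange behaves alike with cyclopropylmethyl or 2-chlorophenyl on the sulfonyl sulfur.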